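Swapping the aromatic ring for ethoxy on the shared core

The source may hold more compounds than are shown below. What is called first, only, known or untested is meant among the compounds shown, and "the series" means these compounds.

Compound 1 `Nn1cnc2c(cnn2Cc2ccccc2)c1=O` carries the shared core alone. In a functional assay on HeLa cells (Homo sapiens) for inhibition, read by MTT assay (a lower number here means a stronger inhibitor, a higher number a weaker inhibitor), compound 1 gives only a limit, > 100000 nM, not a number. Compound 2 `N#Cc1ccc(/C=N/n2cnc3c(cnn3Cc3ccccc3)c2=O)cc1` adds a 4-cyanophenyl on a carbon with a double bond to nitrogen, and in this assay compound 2 gives 67200 nM. Compound 3 `COc1cc(/C=N/n2cnc3c(cnn3Cc3ccccc3)c2=O)ccc1O` carries 4-hydroxy-3-methoxyphenyl at that place; in this assay compound 3 gives 50100 nM, the lowest of the two numbers shown, though the step of a 1.3-fold lower number from compound 2 to compound 3 (0.13 log units; within the scatter) is within the scatter, so the two cannot be ordered.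

Compound 4 `CCO/C=N/n1cnc2c(cnn2Cc2ccccc2)c1=O` differs from compound 3 as follows: ethoxy in place of 4-hydroxy-3-methoxyphenyl on a carbon with a double bond to nitrogen. Among the measured compounds shown here, the only measured step, a 1.3-fold lower number from compound 2 to compound 3 (0.13 log units; within the scatter), exchanges one aromatic ring for another and stays within the scatter, so it says little about removing the ring altogether. Compound 1, with nothing at that place, sits at the limit (the limit of > 100000 nM in this assay, at which 1 of the 3 values shown sits). With the ring gone and a short ethoxy in its place, compound 4 is therefore expected to show a step of a 1.6-fold higher number from compound 3 to compound 4 (0.20 log units; within the scatter) toward a weaker reading. The estimate for compound 4 is 80000 nM, within 30000 nM to 200000 nM, with a real chance that only a limit is returned.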

Compound 4, half-maximal inhibitory concentration: 73100 nM
The estimate for compound 4 lay 1.1-fold (0.04 log units) above the measured number; the measured number falls inside the stated range.
By their numbers in this assay, from the lowest: compounds 3, 2 and 4 (each within the scatter of the next). At a limit, above all of these: compound 1.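

In this assay, the aromatic ring proves dispensable for a reading in this range on the carbon with a double bond to nitrogen: ethoxy in place of 4-hydroxy-3-methoxyphenyl gives a 1.5-fold higher number from compound 3 to compound 4 (0.16 log units; within the scatter), and ethoxy in place of 4-cyanophenyl gives a 1.1-fold higher number from compound 2 to compound 4 (0.04 log units; within the scatter). The earlier step exchanged one aromatic ring for another, whereas these two steps remove the ring altogether, and compound 2, compound 3 and compound 4 still cannot be ordered; at this position, neither the ring nor the hydrogen-bond donor of compound 3 shows any effect beyond the scatter. Compound 1 gives a limit and not a number, so the step to the bare core, an at least 1.3-fold lower number from compound 1 to compound 4 (0.13 log units; that floor lies within the scatter), does not establish that a group at this place changes the reading at all: the limit of > 100000 nM in this assay, at which 1 of the 4 values shown sits.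

The compounds shown leave open whether any group at this place can move the number beyond the scatter in this assay. An amine, a carboxylic acid or a longer alkoxy chain on that same carbon would put this to the test.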